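The compounds below may be only part of what the source reports. "The series", "measured", "known", "first", "only" and "open" are said of these compounds alone.

Compounds measured in an assay on CHO cells for antagonist activity at transient receptor potential cation channel subfamily V member 1 (Homo sapiens), read by FLIPR; a higher number here means a weaker inhibitor, a lower number a stronger inhibitor:
Compound 1 `CCCCN(C)c1cc(C(F)(F)F)ccc1CNC(=O)C(C)c1ccc(NS(C)(=O)=O)c(F)c1` gives 1.2 nM.
Compound 2 `CCCN(CCC)c1cc(C(F)(F)F)ccc1CNC(=O)C(C)c1ccc(NS(C)(=O)=O)c(F)c1` gives 0.3 nM.
Compound 3 `CC(C(=O)NCc1ccc(C(F)(F)F)cc1OCc1ccc(F)cc1)c1ccc(NS(C)(=O)=O)c(F)c1` gives 0.5 nM.

Compound 2 holds the lowest number of the three. Its nearest neighbour is compound 3, a 1.7-fold higher number from compound 2 to compound 3 (0.22 log units; within the scatter), which sits within the scatter; compound 1 stands further off, a 4.0-fold lower number from compound 1 to compound 2 (0.60 log units; beyond the scatter), beyond it. Compound 4 `CC(C(=O)NCc1ccc(C(F)(F)F)cc1SC1CCCCC1)c1ccc(NS(C)(=O)=O)c(F)c1` differs from compound 2 by cyclohexylsulfanyl in place of dipropylamino on an aromatic carbon. Going by the values given here, two measured steps concern this same aromatic carbon: a 4.0-fold lower number from compound 1 to compound 2 (0.60 log units; beyond the scatter) and a 1.7-fold higher number from compound 2 to compound 3 (0.22 log units; within the scatter). The exchange of dipropylamino for a ring-bearing group in compound 3 stayed within the scatter, so the expected step in this assay is likewise small, a 1.7-fold higher number from compound 2 to compound 4 (0.22 log units; within the scatter). Compound 4 is therefore estimated at 0.5 nM, with a range from 0.15 nM to 2 nM.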

Compound 4, inhibition constant: 0.5 nM
Beside the measured number, compound 4's estimate shows no gap at the digits printed; measured number inside the range.
By their numbers in this assay, from the lowest: compounds 2, 3 and 4 (each within the scatter of the next); then compound 1.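

In this assay, a ring-bearing group attached through sulfur fits the pattern at this aromatic carbon: there is a 1.7-fold higher number from compound 2 to compound 4 (0.22 log units; within the scatter), and no change at the digits printed from compound 3 to compound 4 (within the scatter), so groups attached through nitrogen, oxygen and sulfur are not told apart among compounds 2, 3 and 4. Compound 1 goes against this pattern, with a 2.4-fold lower number from compound 1 to compound 4 (0.38 log units; beyond the scatter). No measurement shown offers an explanation for these results. The compounds shown leave open how a much smaller group, such as methoxy or a lone hydrogen, would read at this carbon. They also leave open whether a carboxylic acid there would hold the number.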